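Bromo Added to the Anilide Ring of a Pyrazole Carboxamide

The source may report more compounds than this note shows. Statements on the series, on what has been measured and on what is new or still open speak of the compounds shown alone.

Measured compounds:
compound 1, `COc1ccc(-c2nn(-c3ccccc3)cc2C(=O)Nc2ccc(Br)cc2)cc1`, 5870 nM
compound 2, `O=C(Nc1ccccc1)c1cn(-c2ccccc2)nc1-c1ccc([N+](=O)[O-])cc1`, 2010 nM

Of the compounds shown here, two have been measured in a functional assay on HCT-116 cells (Homo sapiens) for cytotoxicity, read by MTT assay, with a stated time of 48 h; a lower number here means a stronger inhibitor, a higher number a weaker inhibitor. Compound 1 gives 5870 nM, and compound 2 gives 2010 nM. Compound 2 therefore stands at the lower of the two numbers, and the gap to compound 1 lies beyond the scatter. The two structures differ in two places at once, so the values alone say nothing about either change on its own.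

Compound 3, `O=C(Nc1ccc(Br)cc1)c1cn(-c2ccccc2)nc1-c1ccc([N+](=O)[O-])cc1`, has not yet been measured. It differs from compound 2 in one respect: bromo in place of hydrogen on an aromatic carbon. For the measured compounds named here, no measured pair isolates this change, so the step is uncertain; the expectation is a step in this assay of a 1.2-fold higher number from compound 2 to compound 3 (0.09 log units; within the scatter), that is, none beyond the scatter, with the wider range allowing for a modest weakening. Compound 3 is expected to give about 2500 nM, estimated between 1000 nM and 6500 nM.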

Compound 3, half-maximal inhibitory concentration: 4080 nM
Beside the measured number, compound 3's estimate is 1.6-fold (0.21 log units) below it, and the stated range covers the measured number.
By their numbers in this assay, from the lowest: compound 2; then compounds 3 and 1 (each within the scatter of the next).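

With the bromo change now isolated, this assay shows a 2.0-fold higher number from compound 2 to compound 3 (0.31 log units; beyond the scatter), a modest weakening when phenylcarbamoyl becomes (4-bromophenyl)carbamoyl, which the first two compounds could not separate from their second difference. With bromo held in place, nitro in place of methoxy on an aromatic carbon gives a 1.4-fold lower number from compound 1 to compound 3 (0.16 log units; within the scatter), so in this pair that exchange shows no step beyond the scatter. No measurement here bears on the reason for either step.

The compounds shown leave open whether the bromo step holds when methoxy rather than nitro is present on the other ring. They also leave open how the same place responds to a different group, such as chloro, an amine or a carboxylic acid.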